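This account rests on a few compounds, and the source may have more. Where it says the series, first, only, none or still open, it means among the compounds named here.

Measured compounds:
compound 1 `ClCc1ccc(Cn2cnc3c(Cl)ncnc32)cc1`, result in a functional assay on SW-620 cells (Homo sapiens) for cytotoxicity, read by sulforhodamine B assay, with a stated time of 48 h; on this read-out higher numbers stand for weaker inhibition of growth and lower numbers for stronger inhibition of growth: "not determined" (no result reported)
compound 2 `ClCc1ccccc1Cn1cnc2c(Cl)nc(Cl)nc21`, 150 nM

Going by the values given here, compound 1 stands nowhere on the numbers: in this assay compound 1 carries no single value, so no step from it can be measured or sized. Compound 3 `ClCc1ccc(Cn2cnc3c(Cl)nc(Cl)nc32)cc1` differs from compound 1 by chloro in place of hydrogen on an aromatic carbon. With no value for compound 1, the direction of this step cannot be stated beyond the change itself. Among the compounds with values here, the only anchor is compound 2, which carries the same pair of chloro groups on the shared core and gives 150 nM. On that basis compound 3 is expected near 200 nM, within 60 nM to 700 nM.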

Compound 3, concentration for 50% growth inhibition: 3800 nM
Compound 3: the middle estimate sits 19-fold (1.28 log units) below what was measured; measured number outside the range, above it.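

Going by these compounds alone, with compound 3 at 3800 nM and compound 1 without a single value, no step between them can be read. The compounds shown leave open what chloro in place of hydrogen on the shared core changes. No evidence bears on this result.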